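Pyridine-oxide in place of the sulfonamidophenyl on the piperazine

The compounds below may be only part of what the source reports. "The series", "measured", "known", "first", "only" and "open" are said of these compounds alone.

Compound 2 `CS(=O)(=O)Nc1ccccc1N1CCN(CCCCCC(=O)NC2CCCc3ccccc32)CC1` gives the highest of the two numbers in an assay on HEK293 cells for displacement of a labelled ligand from 5-hydroxytryptamine receptor 7 (Rattus norvegicus) (a lower number here means a stronger inhibitor, a higher number a weaker inhibitor), at 4250 nM; compound 1 `CC(C)(C)c1ccccc1N1CCN(CCCCCC(=O)NC2CCCc3ccccc32)CC1` gives 538 nM. Compound 3 `O=C(CCCCCN1CCN(c2cccc[n+]2[O-])CC1)NC1CCCc2ccccc21` differs from compound 2 by a group of 7 heavy atoms (5 carbon, 1 nitrogen, 1 oxygen; one six-membered aromatic ring with 1 hetero atom) in place of a group of 11 heavy atoms (7 carbon, 1 nitrogen, 2 oxygen, 1 sulfur; one six-membered aromatic ring of carbon only), on an amine nitrogen in a ring. For the measured compounds named here, no measured step covers this exchange. Going by the values given here, the only step known, a 7.9-fold higher number from compound 1 to compound 2 (0.90 log units; beyond the scatter), changes just the substituent on the aryl ring, so it fixes no direction here. Expected for compound 3 is a 1.4-fold lower number from compound 2 to compound 3 (0.15 log units; within the scatter) in this assay, i.e. no step beyond the scatter, with wide uncertainty. The estimate for compound 3 is 3000 nM, within 600 nM to 12000 nM.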

Compound 3, inhibition constant: 8030 nM
Beside the measured number, compound 3's estimate is 2.7-fold (0.43 log units) below it; low and high end bracket the measured number.
By their numbers in this assay, from the lowest: compound 1; then compounds 2 and 3 (each within the scatter of the next).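

In this assay the pyridine-oxide exchange gives a 1.9-fold higher number from compound 2 to compound 3 (0.28 log units; within the scatter) on the ring amine nitrogen, so the 2-(methanesulfonamido)phenyl and the pyridine-oxide are not told apart here. The same pyridine-oxide set against the tert-butyl-bearing phenyl gives a 15-fold higher number from compound 1 to compound 3 (1.17 log units; beyond the scatter) and is a large step, so among these groups only the tert-butyl-bearing phenyl of compound 1 stands apart. No supporting measurement speaks to a cause. Still open, going by these compounds, is whether a pyridine ring without the oxide oxygen, or an unsubstituted phenyl, on the same nitrogen falls with compound 1 or with compound 3.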